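The source may report more compounds than this note shows. Statements on the series, on what has been measured and on what is new or still open speak of the compounds shown alone.

Measured in a functional assay on HCT-116 cells (Homo sapiens) for cytotoxicity, read by MTT assay, with a stated time of 72 h; a higher number here means a weaker inhibitor, a lower number a stronger inhibitor:
- compound 1 `CC1(C)O[C@@H](CO)[C@H](Cn2cc(Cn3c4c(c5ccccc53)C(=O)c3c[n+]([O-])c5ccccc5c3C4=O)nn2)O1`: 130 nM
- compound 2 `CC1(C)OC[C@H](Cn2cc(Cn3c4c(c5ccccc53)C(=O)c3c[n+]([O-])c5ccccc5c3C4=O)nn2)O1`: 130 nM
- compound 3 `O=C1c2c[n+]([O-])c3ccccc3c2C(=O)c2c1c1ccccc1n2CCCCN1CCCCC1`: 200 nM

Compound 3, at 200 nM, lies within the usual scatter of both compound 1 and compound 2, so the three values do not separate. The next compound, compound 4 `O=C1c2c[n+]([O-])c3ccccc3c2C(=O)c2c1c1ccccc1n2Cc1cn(C[C@@H](O)CO)nn1`, keeps the shared core and changes the side chain: 1-(2,3-dihydroxypropyl)-1H-1,2,3-triazol-4-yl in place of 3-(piperidin-1-yl)propyl on a saturated chain carbon bound to an aromatic nitrogen. The new group, 1-(2,3-dihydroxypropyl)-1H-1,2,3-triazol-4-yl, sits on a saturated chain carbon bound to an aromatic nitrogen.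

Within the data shown here, no measured step makes this exchange. Among the measured compounds shown here, the only one available is no change at the digits printed from compound 1 to compound 2 (within the scatter), which places hydrogen in place of hydroxymethyl on a saturated ring carbon. It bears only indirectly, as compound 1 and compound 2 also carry a triazole, and that change left the value at 130 nM for compound 2. For the measured compounds named here, no measured compound carries the 2,3-dihydroxypropyl group itself, so the uncertainty is wide. Nothing shown points to a step beyond the scatter in either direction in this assay. An estimated 1.1-fold lower number from compound 3 to compound 4 (0.05 log units; within the scatter) is therefore expected to remain within the scatter. For compound 4 the expected value is 180 nM, with an estimated range from 70 nM to 450 nM.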

Compound 4, half-maximal inhibitory concentration: 190 nM
Estimate against measurement, compound 4: 1.1-fold (0.02 log units) below, within the range that was stated.
By their numbers in this assay, from the lowest: compounds 1, 2, 4 and 3 (each within the scatter of the next).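

In this assay the exchange of 3-(piperidin-1-yl)propyl for 1-(2,3-dihydroxypropyl)-1H-1,2,3-triazol-4-yl on a saturated chain carbon bound to an aromatic nitrogen gives a 1.1-fold lower number from compound 3 to compound 4 (0.02 log units; within the scatter) and so shows that these two side chains are not told apart at this position, although they differ in ring type and in their counted hydrogen-bond donors and acceptors. Among the triazoles, 1,2-dihydroxyethyl in place of 2,2-dimethyl-1,3-dioxolan-4-yl gives a 1.5-fold higher number from compound 2 to compound 4 (0.16 log units; within the scatter) and 1,2-dihydroxyethyl in place of 5-(hydroxymethyl)-2,2-dimethyl-1,3-dioxolan-4-yl gives a 1.5-fold higher number from compound 1 to compound 4 (0.16 log units; within the scatter) and so the value does not depend on keeping the dioxolane ring. Nothing available gives a reason for this lack of separation.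

The compounds shown leave open whether a carboxylic acid, a primary amine or a much longer alkyl chain in this side chain would produce a step beyond the scatter. They also leave open whether the opposite configuration at the stereocentre of the 2,3-dihydroxypropyl group would matter.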